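A few compounds are considered here, and "the series" means these few. Any claim that something is new, unique, unknown or untested is made for them only; others in the source may bear on it.

Compound 3 `Nc1nc(N2CCCC2)c2ncn(/C=C3/CC3(CO)CO)c2n1` carries pyrrolidin-1-yl on the shared core. In an ADME assay on BCBL1 cells (Homo sapiens) for cytotoxicity, with a stated time of 7 days (a higher number here means that more compound is tolerated, a lower number that less compound is tolerated), compound 3 gives > 20000 nM, which is a limit of the assay and not a number. Compound 1 `CC(C)Nc1nc(N)nc2c1ncn2/C=C1/CC1(CO)CO` gives > 20000 nM in this assay, again only a limit. Compound 2 `Nc1nc2c(ncn2/C=C2/CC2(CO)CO)c(=O)[nH]1` gives > 20000 nM in this assay, also a limit. Among the measured compounds shown here, the one comparable step, a step that the two limits leave unreadable from compound 1 to compound 3, cannot be read because of the limit of > 20000 nM in this assay, at which 3 of the 3 values shown sit. Compound 4 `CCCCOc1nc(N)nc2c1ncn2/C=C1/CC1(CO)CO` differs from compound 3 in this way: butoxy in place of pyrrolidin-1-yl on an aromatic carbon. For the measured compounds named here, no measured step bears on this change with a readable size; the three values shown all sit at one limit. Compound 4 is therefore expected to tolerate about 20000 nM, most likely between 10000 nM and 40000 nM. The expected step is then a number no higher from compound 3 to compound 4 (the limit leaves the size open), nothing beyond the scatter.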

Compound 4, half-maximal cytotoxic concentration: > 20000 nM
Compound 4: only a limit was reported; the forecaster's own chance of this, stated with the estimate: 80%; the middle value lies on the limit itself.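

Among the compounds shown here, compound 4 gives only a limit as well, so no step among compound 1, compound 3 and compound 4 can be read, because all the values rest on one limit: the limit of > 20000 nM in this assay, at which 4 of the 4 values shown sit. The compounds shown leave open whether isopropylamino, pyrrolidin-1-yl and butoxy differ at all in this assay.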